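The compounds below may be only part of what the source reports. "The series", "measured", "known", "first", "only" and "open" are said of these compounds alone.

In a functional assay on COLO 205 cells (Homo sapiens) for inhibition, read by sulforhodamine B assay, with a stated time of 48 h, tested at 50 uM (on this read-out higher numbers stand for more inhibition of growth at the one concentration tested and lower numbers for less inhibition of growth), compound 2 `COc1ccc(/C=C/C(=O)/C=C/c2ccc(OCc3cn(CCOc4cc(=O)oc5ccccc45)nn3)c(OC)c2)cc1OC` gives 80%. This value lies within the scatter of both other measured compounds: compound 1 `COc1cc(/C=C/C(=O)/C=C/c2cccc3ccccc23)ccc1OCc1cn(CCOc2cc(=O)oc3ccccc23)nn1` gives 85% and compound 3 `COc1cc(/C=C/C(=O)/C=C/c2cc(OC)c(OC)c(OC)c2)ccc1OCc1cn(CCCOc2cc(=O)oc3ccccc23)nn1` gives 74%. Compound 4 `COc1ccc(/C=C/C(=O)/C=C/c2ccc(OCc3cn(CCOc4cc(=O)oc5ccccc45)nn3)c(OC)c2)cc1` has not yet been measured in this assay. It differs from compound 2 in one place: hydrogen in place of methoxy on an aromatic carbon. Cut one bond further out, this reads 3,4-dimethoxyphenyl to 4-methoxyphenyl.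

One measured step involves this same end of the molecule: a number 5 percentage points lower from compound 1 to compound 2 (within the scatter). That exchange of naphthalen-1-yl for 3,4-dimethoxyphenyl stayed within the scatter. Within the data shown here, no measured step removes a single methoxy on its own, so this evidence is only indirect. No step beyond the scatter is therefore expected, and no direction is favoured. The estimated step is a number 2 percentage points lower from compound 2 to compound 4 (within the scatter). Compound 4 is estimated at 78%, with an expected range from 66% to 88%.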

Compound 4, percent growth inhibition at one concentration: 68%
Estimate against measurement, compound 4: 10 percentage points above, and the stated range covers the measured number.
By their numbers in this assay, from the lowest: compounds 4, 3, 2 and 1 (each within the scatter of the next, the first and the last beyond it).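

In this assay, among these compounds, the methoxy position gives the first step beyond the scatter: removing this methoxy, which sits ortho to a methoxy group, gives a number 12 percentage points lower from compound 2 to compound 4 (beyond the scatter) in this series. The 4-methoxyphenyl end also separates from naphthalen-1-yl, with a number 17 percentage points lower from compound 1 to compound 4 (beyond the scatter) on that exchange, whereas the step from naphthalen-1-yl to 3,4-dimethoxyphenyl stayed within the scatter. The aryl end is therefore not indifferent to substitution, though nothing available explains the loss of growth inhibition.

Open, as far as these compounds go, is whether the methoxy itself matters or whether another group at this aromatic carbon, such as hydroxy, fluorine or an amine, would serve equally well. Also open, from the compounds shown here alone, is how a longer alkoxy group there would read, and whether the step holds at concentrations other than the single one tested.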